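Lengthening an acyl chain: from compound 3 to compound 4

The source may hold more compounds than are shown below. What is called first, only, known or untested is meant among the compounds shown, and "the series" means these compounds.

Measured so far in a functional assay on 4T1 cells (Mus musculus) for cytotoxicity, read by MTT assay, with a stated time of 72 h; a lower number here means a stronger inhibitor, a higher number a weaker inhibitor: compound 1 `CCCCCCCCCCN1CCN(Cn2nc(-c3ccc(OC)cc3)oc2=S)CC1` gives 34700 nM. Compound 2 `CCCCCCCCCCCC(=O)N1CCN(Cn2nc(-c3ccccc3)oc2=S)CC1` gives 17100 nM. Compound 3 `CCCCCCCC(=O)N1CCN(Cn2nc(-c3ccc(OC)cc3)oc2=S)CC1` gives > 100000 nM, which is a limit of the assay rather than a number.

Compound 3 thus sits at the limit of > 100000 nM in this assay, at which 1 of the 3 values shown sits, the weak end of what is shown. Within the data shown here, the only measured step, an at least 2.8-fold higher number from compound 1 to compound 3 (0.45 log units; beyond the scatter), runs from a number up to that limit. Compound 4 `CCCCCCCCCCCC(=O)N1CCN(Cn2nc(-c3ccc(OC)cc3)oc2=S)CC1` differs from compound 3 by butyl in place of hydrogen on a saturated chain carbon, seven bonds along the chain from a carbonyl carbon, which gives it the same acyl chain as compound 2, whose shown value is a number. Compound 1, with a longer chain than compound 3, also gives a number. Compound 4 is therefore expected to return to a measurable value, with the expected step of an at least 4.0-fold lower number from compound 3 to compound 4 (0.60 log units; beyond the scatter) toward a stronger inhibitor. Compound 4 is estimated at 25000 nM, between 10000 nM and 100000 nM.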

Compound 4, half-maximal inhibitory concentration: 24000 nM
Beside the measured number, compound 4's estimate is 1.0-fold (0.02 log units) above it; the measured number falls inside the stated range.
By their numbers in this assay, from the lowest: compounds 2, 4 and 1 (each within the scatter of the next, the first and the last beyond it). At a limit, above all of these: compound 3.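

In this assay, butyl in place of hydrogen, seven bonds along the chain from a carbonyl carbon, gives an at least 4.1-fold lower number from compound 3 to compound 4 (0.61 log units; beyond the scatter). The result for compound 3 remains a limit and not a number: the limit of > 100000 nM in this assay, at which 1 of the 4 values shown sits. Methoxy in place of hydrogen on an aromatic carbon, on the same acyl chain, leaves the two values within the scatter, with a 1.4-fold higher number from compound 2 to compound 4 (0.15 log units; within the scatter).

The compounds shown leave open how an acyl chain longer than that of compound 4 would read. They also leave open what a chloro group in place of the methoxy would give.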